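Swapping a Benzyl Chloro for Methoxy in an Indole Hydrazone Series

This account rests on a few compounds, and the source may have more. Where it says the series, first, only, none or still open, it means among the compounds named here.

Measured compounds:
compound 1, `O=C(N/N=C\c1cn(Cc2ccc(Cl)cc2)c2cc(F)ccc12)c1c[nH]c2ccccc12` — 6000 nM
compound 2, `O=C(N/N=C\c1cn(Cc2ccc(Cl)cc2)c2cc(F)ccc12)c1c[nH]c2ccc(Br)cc12` — 8300 nM

In a functional assay on MCF7 cells (Homo sapiens) for cytotoxicity (a higher number here means a weaker inhibitor, a lower number a stronger inhibitor), compound 1 gives 6000 nM, the lower of the two numbers available; its nearest neighbour is compound 2, and the step of a 1.4-fold higher number from compound 1 to compound 2 (0.14 log units; within the scatter) lies within the scatter, so the two cannot be separated. Compound 3, `COc1ccc(Cn2cc(/C=N\NC(=O)c3c[nH]c4ccccc34)c3ccc(F)cc32)cc1`, has not yet been measured in this assay. It differs from compound 1 in a single way: methoxy in place of chloro on an aromatic carbon. Within the data shown here, no measured step touches that part of the shared core; the only measured step changes the other aromatic ring and is small. The data therefore give no firm direction, and the best expectation is a step of modest size, if any, with the estimate for compound 3 amounting to a 1.3-fold higher number from compound 1 to compound 3 (0.12 log units; within the scatter). Compound 3 is accordingly estimated to give 8000 nM in this assay, with a plausible range from 3000 nM to 25000 nM.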

Compound 3, half-maximal inhibitory concentration: 13100 nM
The estimate for compound 3 lay 1.6-fold (0.21 log units) below the measured number, within the range that was stated.
By their numbers in this assay, from the lowest: compounds 1, 2 and 3 (each within the scatter of the next, the first and the last beyond it).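

The position on the benzyl group, which the earlier pair left untouched, can move the number in this assay: methoxy in place of chloro gives a 2.2-fold higher number from compound 1 to compound 3 (0.34 log units; beyond the scatter) and so a modest step towards weaker inhibition. Among these compounds, this is the first step in the set to lie beyond the scatter, whereas the bromo step on the other aromatic ring could not be separated from compound 1. Nothing available accounts for this step or ties it to any feature of either group.

Going by these compounds, it remains open whether a hydroxy, an amine or a methyl at this same place would give a higher or lower number than chloro. On these data alone, it is also open whether methoxy in place of chloro would give a step of similar size on compound 2, which carries the bromo group.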